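Phenyl to methyl on a shared core: an expected step

This account rests on a few compounds, and the source may have more. Where it says the series, first, only, none or still open, it means among the compounds named here.

Three compounds have been measured in a functional assay on the whole organism with Rattus norvegicus as the target, at a dose of 100 mg/kg; on this read-out higher numbers stand for more inhibition at the one dose given (going by the name of the read-out) and lower numbers for less inhibition:

compound 1 `CC/N=C(/NC#N)NCCCCn1nc(-c2ccccc2)ccc1=O` gives 58.8%
compound 2 `C/N=C(/NC#N)NCCCCCn1nc(-c2ccccc2)ccc1=O` gives 47.6%
compound 3 `C/N=C(/NC#N)NCCCCCn1nc(C)ccc1=O` gives 14.9%

Compound 1 stands highest of the three. The cores of compound 1 and compound 2 differ: a group of 8 heavy atoms (4 carbon, 4 nitrogen; no ring) in place of a group of 8 heavy atoms (4 carbon, 4 nitrogen; no ring), on a saturated chain carbon, four bonds along the chain from an aromatic nitrogen. That difference goes with a step of a number 11.2 percentage points lower from compound 1 to compound 2 (beyond the scatter), which is modest but beyond the scatter.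

The change from compound 2 to compound 3 is methyl in place of phenyl on an aromatic carbon, and it is followed by a large step of a number 32.7 percentage points lower from compound 2 to compound 3 (beyond the scatter).

Compound 4 `CC/N=C(/NC#N)NCCCCn1nc(C)ccc1=O` has not yet been measured. Within the data shown here, it differs from compound 1 by methyl in place of phenyl on an aromatic carbon, which is the same change as the one from compound 2 to compound 3, made here on the core of compound 1 instead. Among the measured compounds shown here, since that change cost a number 32.7 percentage points lower from compound 2 to compound 3 (beyond the scatter) in the only pair where it was measured, a step of about the same size is expected, namely a number 32.8 percentage points lower from compound 1 to compound 4 (beyond the scatter). Compound 4 is therefore estimated at 26%, with a plausible span from 10% to 42%; this rests on a single measured pair, so the span is kept wide.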

Compound 4, a percentage reported as inhibition, in the whole organism at one dose (the size of the read-out at that dose, not a potency): 13.5%
The estimate for compound 4 lay 12.5 percentage points above the measured number; the measured number falls inside the stated range.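

On the core of compound 1, methyl in place of phenyl gives a number 45.3 percentage points lower from compound 1 to compound 4 (beyond the scatter) in this assay. Set beside the earlier case on the other core, the two steps do not differ by more than repeated measurements would be expected to: the same change on two cores in this assay, a number 32.7 percentage points lower (beyond the scatter) from compound 2 to compound 3 and a number 45.3 percentage points lower (beyond the scatter) from compound 1 to compound 4, 12.6 percentage points apart, within the scatter of two such steps. The change therefore carried from one core to the other in direction and, within that scatter, in size, but two pairs cannot establish a rule for further cores in the series, and they do not explain why the number falls.

The compounds shown leave open what other groups would do on this aromatic carbon, since they cover only phenyl and methyl there; an ethyl group or a carboxylic acid, for example, could fall anywhere relative to these two. Also open, going by these compounds, is how a longer chain would behave with phenyl or with methyl on the same carbon.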